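This account rests on a few compounds, and the source may have more. Where it says the series, first, only, none or still open, it means among the compounds named here.

Of the compounds shown here, three have been measured in a functional assay on cardiac atrium for agonist activity at histamine H2 receptor (Cavia porcellus); on this read-out lower numbers stand for smaller maximal responses and higher numbers for larger maximal responses. Compound 1 `N=C(NCCCc1c[nH]cn1)NC(=O)CC(c1ccc(Br)cc1)c1ccc(Br)cc1` gives 60%. Compound 2 `N=C(NCCCc1c[nH]cn1)NC(=O)CC(c1ccccc1)c1nccs1` gives 100%, and compound 3 `N=C(NCCCc1c[nH]cn1)NC(=O)CC(c1ccc(F)c(F)c1)c1nccs1` gives 90%. Among these three numbers compound 3 stands second highest: its nearest neighbour is compound 2, and the single measured step between neighbouring structures, a number 10 percentage points lower from compound 2 to compound 3 (within the scatter), lies within the scatter, while compound 1 sits a number well below compound 3, beyond the scatter.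

Compound 4 `N=C(NCCCc1c[nH]cn1)NC(=O)CC(c1ccc(F)c(F)c1)c1ncc[nH]1` has not yet been measured. It differs from compound 3 in one place: 1H-imidazol-2-yl in place of 1,3-thiazol-2-yl on a saturated chain carbon bound to an aromatic carbon and a saturated chain carbon. For the measured compounds named here, the only measured step concerns a different part of the molecule, the 3,4-difluorophenyl in place of phenyl, and not the five-membered aromatic ring that is exchanged here. Going by the values given here, no measured step therefore bears directly on replacing 1,3-thiazol-2-yl by 1H-imidazol-2-yl, and the numbers give no ground to expect a change beyond the scatter in this assay in either direction. The step of a number 5 percentage points lower from compound 3 to compound 4 (within the scatter) is what is expected. Compound 4 is accordingly estimated to give 85% in this assay, with a range from 65% to 100%.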

Compound 4, largest response reached (Emax), in percent of the reference or control that the assay uses: 100%
Compound 4: middle estimate off by 15 percentage points, on the low side; low and high end bracket the measured number.
By their numbers in this assay, from the lowest: compound 1; then compounds 3, 2 and 4 (each within the scatter of the next).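

On a saturated chain carbon bound to an aromatic carbon and a saturated chain carbon, 1H-imidazol-2-yl can take the place of 1,3-thiazol-2-yl with no clear effect on the maximal response in this assay, the result being a number 10 percentage points higher from compound 3 to compound 4 (within the scatter) and so too small to separate the two compounds. For the compounds shown here, this is the first measured change of the five-membered aromatic ring, since the earlier step concerned only the phenyl group, and it shows that this position tolerates replacing sulfur with nitrogen and exchanging a ring with 0 hydrogen-bond donors and 2 hydrogen-bond acceptors for one with 1 hydrogen-bond donor and 1 hydrogen-bond acceptor. No measurement at hand accounts for this result.

On these data alone, it remains open whether a group of a different kind at this position, such as a six-membered pyridin-2-yl ring or a simple amine, would keep the response at this level. As far as these compounds go, it is also open whether a methyl group on the ring nitrogen of the 1H-imidazol-2-yl would matter, and whether that ring would give a similar response with plain phenyl in place of 3,4-difluorophenyl.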